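Branching the Alkyl Chain at an Aromatic Carbon

The compounds below may be only part of what the source reports. "The series", "measured", "known", "first", "only" and "open" are said of these compounds alone.

Compound 1 `Nc1cc(C2CCCCC2)nc2ccc(NC(=O)/C=C/c3ccc(C(F)(F)F)cc3)cc12` and compound 2 `CCc1cc(N)c2cc(NC(=O)/C=C/c3ccc(C(F)(F)F)cc3)ccc2n1` share a common core and differ only in the group carried on one aromatic carbon. In an assay on isolated protein for displacement of a labelled ligand from melanin-concentrating hormone receptor 1 (Homo sapiens) (a higher number here means a weaker inhibitor, a lower number a stronger inhibitor), compound 1 gives 1.2 nM, and compound 2 gives 1.2 nM. The step of no change at the digits printed from compound 1 to compound 2 (within the scatter) shows that replacing cyclohexyl with ethyl at that carbon leaves the read-out where it was, within the scatter. On the numbers at hand compound 2 thus stands level with compound 1, with no order between them.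

Compound 3 `CCC(C)c1cc(N)c2cc(NC(=O)/C=C/c3ccc(C(F)(F)F)cc3)ccc2n1` carries the change ethyl in place of hydrogen on a saturated chain carbon bound to an aromatic carbon and a saturated chain carbon: on the saturated chain carbon bound to an aromatic carbon and a saturated chain carbon, a hydrogen gives way to ethyl, so that the ethyl of compound 2 becomes sec-butyl. Within the data shown here, the only measured step that bears on this position is no change at the digits printed from compound 1 to compound 2 (within the scatter), in which a cyclohexyl and an ethyl were read alike. Because of no change at the digits printed from compound 1 to compound 2 (within the scatter), a sec-butyl at the same aromatic carbon is expected to be tolerated as well, and the expected step of a 1.1-fold higher number from compound 2 to compound 3 (0.03 log units; within the scatter) is none beyond the scatter. Compound 3 is therefore estimated at 1.3 nM, with a range from 0.5 nM to 3.5 nM.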

Compound 3, half-maximal inhibitory concentration: 0.3 nM
Beside the measured number, compound 3's estimate is 4.3-fold (0.64 log units) above it; measured number outside the range, below it.
By their numbers in this assay, from the lowest: compound 3; then compounds 1 and 2 (each within the scatter of the next).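

In this assay, the group on this aromatic carbon now makes a difference that the earlier pair did not reveal: adding ethyl on the saturated chain carbon bound to an aromatic carbon and a saturated chain carbon gives a 4.0-fold lower number from compound 2 to compound 3 (0.60 log units; beyond the scatter). Replacing cyclohexyl with sec-butyl at the same aromatic carbon gives a 4.0-fold lower number from compound 1 to compound 3 (0.60 log units; beyond the scatter), so sec-butyl separates from both groups that had read alike, and the read-out does not simply run in step with the size of the group across these three compounds. Nothing among the data shown accounts for this step.

The change from ethyl to sec-butyl both lengthens the chain and adds a branch, so these compounds leave open which of the two goes with the lower number, a question that an unbranched butyl chain and an isopropyl group at the same carbon could help to separate. They also leave open how far the trend extends, whether to a tert-butyl group or a longer branched chain, and whether the two mirror-image forms of sec-butyl read alike.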